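This account rests on a few compounds, and the source may have more. Where it says the series, first, only, none or still open, it means among the compounds named here.

Two compounds have been measured so far:

Compound 1, `COc1ccc(C(=O)/C=C/c2cc(OC)c(OC)cc2OC)cc1`: 33900 nM

Compound 2, `COc1cc(OC)c(OC)cc1/C=C/C(=O)c1ccc(Cl)c([N+](=O)[O-])c1`: 16400 nM

Both were tested in a functional assay on MCF7 cells (Homo sapiens) for inhibition, read by MTT assay, with a stated time of 72 h; on this read-out higher numbers stand for weaker inhibition and lower numbers for stronger inhibition. Of the two numbers, compound 1 holds the higher one, which on this read-out means the weaker inhibition; compound 2 comes out lower, and the gap between them is beyond the usual scatter of repeated measurements. Within the data shown here, of that pair only the two values themselves can be spoken of, as no single-change step links them.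

The next compound, compound 3, `COc1cc(OC)c(OC)cc1/C=C/C(=O)c1ccc(Br)cc1`, keeps the core of compound 1 and differs from it in one spot: bromo in place of methoxy on an aromatic carbon. Among the measured compounds shown here, no step between measured compounds isolates a change of this kind, so any expectation rests on the two values in hand alone. The step of a 1.7-fold lower number from compound 1 to compound 3 (0.23 log units; within the scatter) is expected to be modest and downward, toward a somewhat lower number, though it could well stay within the scatter. Compound 3 is accordingly estimated at 20000 nM, with a likely range from 7000 nM to 60000 nM.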

Compound 3, half-maximal inhibitory concentration: 18300 nM
Estimate against measurement, compound 3: 1.1-fold (0.04 log units) above; the measured number falls inside the stated range.
By their numbers in this assay, from the lowest: compounds 2, 3 and 1 (each within the scatter of the next, the first and the last beyond it).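

Among these compounds, the step of a 1.9-fold lower number from compound 1 to compound 3 (0.27 log units; within the scatter) is the first single-change comparison, and it concerns the group at the far end of the 4-methoxyphenyl ring, read in this assay. It shows that this position accepts a real exchange, 4-methoxyphenyl to 4-bromophenyl, without a difference that can be told apart from repeat-to-repeat variation: a two-atom group containing oxygen and counted as a hydrogen-bond acceptor gives way to a single bromine atom with no acceptor, and the number does not clearly move. Nothing measured here bears on what lies behind this result.

One exchange at one position says little about how far this tolerance extends, and a single pair cannot show whether other groups placed on this aromatic carbon, such as an amine, a carboxylic acid or a longer chain like butoxy, would leave the number where it is or shift it beyond the scatter. As far as these compounds go, the methoxy groups on the other ring of the shared core also stay the same in this step, so what changes there would do remains open.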